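The compounds below may be only part of what the source reports. "The series", "measured", "known", "first", "only" and "open" are said of these compounds alone.

Measured compounds:
compound 1, `COc1ccccc1Nc1nc(SCc2ccc(C(F)(F)F)cc2)nc2ccccc12` — in a functional assay on HGC-27 cells (Homo sapiens) for cytotoxicity, read by MTT assay, with a stated time of 72 h (on this read-out lower numbers stand for stronger inhibition and higher numbers for weaker inhibition), compound 1 gives > 50000 nM, a limit of the assay.
compound 2, `COc1ccc(Nc2nc(SCc3ccc(C(F)(F)F)cc3)nc3ccccc23)cc1` — in this assay compound 2 gives 23500 nM.

Among the measured compounds shown here, compound 2 is the only compound of the pair with a numerical value in this assay; the other value is a limit (the limit of > 50000 nM in this assay, at which 1 of the 2 values shown sits). For the measured compounds named here, the one measured step, an at least 2.1-fold lower number from compound 1 to compound 2 (0.32 log units; beyond the scatter), concerns where the methoxy group sits on the phenyl ring and not the size of that group.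

Compound 3, `CCOc1ccc(Nc2nc(SCc3ccc(C(F)(F)F)cc3)nc3ccccc23)cc1`, differs from compound 2 by methyl in place of hydrogen on a saturated chain carbon bound to an oxygen on an aromatic ring. Going by the values given here, no measured step concerns a change of this kind, since the step from compound 1 to compound 2 moves the group rather than lengthening it. The expectation for compound 3 therefore rests on compound 2 alone, and a step of a 1.2-fold lower number from compound 2 to compound 3 (0.07 log units; within the scatter) not beyond the scatter is expected. Compound 3 is estimated at 20000 nM, with a range from 8000 nM to 50000 nM.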

Compound 3, half-maximal inhibitory concentration: 33000 nM
The estimate for compound 3 lay 1.7-fold (0.22 log units) below the measured number; the range from low to high includes it.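

In this assay the change from methoxy to ethoxy gives a 1.4-fold higher number from compound 2 to compound 3 (0.15 log units; within the scatter) and so does not separate the two compounds: at this place, on a saturated chain carbon bound to an oxygen on an aromatic ring, the added methyl leaves no readable mark on the number. Set against the 2-methoxyphenyl compound, the 4-ethoxyphenyl group gives an at least 1.5-fold lower number from compound 1 to compound 3 (0.18 log units; that floor lies within the scatter) and this is weaker evidence than the step from the 4-methoxyphenyl compound, as its floor stays within the scatter. That step can only be read as a floor because the value of compound 1 is a limit: the limit of > 50000 nM in this assay, at which 1 of the 3 values shown sits.

As far as these compounds go, whether a longer chain such as propoxy or butoxy, or an amine or a carboxylic acid in place of the ethoxy group, would move the number beyond the scatter stays open. Also open, from the compounds shown here alone, is whether any change to the trifluoromethyl group or the shared core would do so.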